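Imidazole in place of chlorothiophene on the benzylic carbon

This account rests on a few compounds, and the source may have more. Where it says the series, first, only, none or still open, it means among the compounds named here.

Working notes on the series. All three measured compounds share one core, a carboxylic acid chain on an aryl amine whose nitrogen carries a substituted methylene. Compound 1 `O=C(O)CCCc1ccc(NCc2cccc(Oc3ccccc3)c2)cc1` in a functional assay for agonist activity at Free fatty acid receptor 1 (Homo sapiens) (on this read-out lower numbers stand for an effect already at smaller amounts and higher numbers for an effect only at larger amounts of compound), gives 3160 nM. Compound 2 `O=C(O)CCc1ccc(NCc2cccc(Br)c2)cc1` in this assay gives 794 nM. Compound 3 `O=C(O)CCc1ccc(NCc2ccc(Cl)s2)cc1` in this assay gives 2000 nM.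

On these numbers compound 3 holds the second highest of three. Its gap to compound 1 lies within the scatter, so the two are not distinguished. Its gap to compound 2 lies beyond the scatter, with compound 2 at the lower number.

Compound 4 `O=C(O)CCc1ccc(NCc2ncc[nH]2)cc1` is not yet measured. Its change from compound 3 is 1H-imidazol-2-yl in place of 5-chlorothiophen-2-yl on a saturated chain carbon bound to a nitrogen on an aromatic ring. Within the data shown here, no pair of measured compounds shows this change, so no measured step is available to guide the estimate; what follows rests on the three values shown and on the nature of the exchange.

In this assay the step from compound 3 to compound 4 is expected to be a 5.0-fold higher number from compound 3 to compound 4 (0.70 log units; beyond the scatter), a move toward higher numbers beyond the scatter. Compound 4 is thus estimated at 10000 nM in this assay, with a range of 3000 nM to 40000 nM.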

Compound 4, half-maximal effective concentration: < 31700 nM
Compound 4: no number, only a limit; the forecaster's own chance of this, stated with the estimate: 30%; the middle value does not contradict the limit.
By their numbers in this assay, from the lowest: compound 2; then compounds 3 and 1 (each within the scatter of the next).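

In this assay, among these compounds, compound 4 gives < 31700 nM, a limit and not a number, so no step from compound 3 to compound 4 can be read. The compounds shown leave open how far 1H-imidazol-2-yl in place of 5-chlorothiophen-2-yl on a saturated chain carbon bound to a nitrogen on an aromatic ring moves the number in this assay.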